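Sulfamate series: aryl amine side chains at the amide

The source may report more compounds than this note shows. Statements on the series, on what has been measured and on what is new or still open speak of the compounds shown alone.

Measured so far in an assay on HEK293 cells for inhibition of Steryl-sulfatase (Homo sapiens), tested at 0.1 uM; on this read-out higher numbers stand for a stronger effect at the one concentration tested and lower numbers for a weaker effect:
compound 1 `CN(C)CCN(CCN(C)C)c1ccc(C(=O)N2CCc3ccc(OS(N)(=O)=O)cc3C2)cc1`: 3.8%
compound 2 `NS(=O)(=O)Oc1ccc2c(c1)CN(C(=O)c1cccc(N3CCN(Cc4ccccc4)CC3)c1)CC2`: 0%
compound 3 `CN(CCCN1CCCCC1)c1cccc(C(=O)N2CCc3ccc(OS(N)(=O)=O)cc3C2)c1`: 24.1%

All three share the same sulfamate-bearing core and differ only in the aryl amine attached through the amide. Compound 1 stands second highest of the three numbers in this assay. Its nearest neighbour is compound 2, whose value lies slightly lower but within the scatter, so the two cannot be told apart. Among the measured compounds shown here, compound 3 stands beyond the scatter above compound 1, and is the only value here that rises clearly above the noise.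

Compound 4 `CCCN(Cc1ccccc1)c1ccc(C(=O)N2CCc3ccc(OS(N)(=O)=O)cc3C2)cc1` has not been measured. It departs from compound 1 in one place: benzyl(propyl)amino in place of bis(2-(dimethylamino)ethyl)amino on an aromatic carbon. For the measured compounds named here, no measured pair in the set isolates this change, so the direction can only be reasoned from the spread of the three values, which is narrow and low apart from compound 3.

Given that compound 1 gives 3.8% and compound 2, also carrying a benzyl group on its amine, gives 0%, no step beyond the scatter is expected for compound 4, with a number 4.2 percentage points higher from compound 1 to compound 4 (within the scatter) as the expected change. Compound 4 is estimated at 8%, within 0% to 25%.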

Compound 4, a percentage reported as inhibition, at one concentration (the size of the read-out at that concentration, not a potency): 64.8%
Beside the measured number, compound 4's estimate is 56.8 percentage points below it, outside the stated range (above it).
By their numbers in this assay, from the lowest: compounds 2 and 1 (each within the scatter of the next); then compound 3; then compound 4.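

In this assay, among the compounds shown here, the substituent on this aromatic carbon, para to a large group, proves able to move the read-out strongly: benzyl(propyl)amino in place of bis(2-(dimethylamino)ethyl)amino gives a number 61 percentage points higher from compound 1 to compound 4 (beyond the scatter), the first single-place change that can be read. Both groups count 11 heavy atoms, so the step comes without any change in that count; what differs is the atom make-up, with one six-membered aromatic ring of carbon only entering, no ring leaving, and 1 hydrogen-bond acceptor in place of 3. No measurement at hand says which of these differences carries the step.

The aromatic ring, the propyl chain and the removal of the two 2-(dimethylamino)ethyl arms all change together in this one swap, so the compounds shown do not separate their contributions. A dipropylamino group, with the ring gone, or a benzylamino group, with the propyl chain gone, would show in this assay whether the reading depends on one part of the amine or on both.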